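Inverting the ring stereocentre of compound 1

The compounds below may be only part of what the source reports. "The series", "measured", "known", "first", "only" and "open" are said of these compounds alone.

In a functional assay on SK-OV-3 cells (Homo sapiens) for inhibition, read by MTT assay (on this read-out lower numbers stand for stronger inhibition and higher numbers for weaker inhibition), compound 1 `COc1ccc(/C=C2\c3cc(OC)c(OC)c(OC)c3CC[C@@H]2O)cc1C(N)=O` gives 1440 nM as its reading. Compound 3 `COc1ccc(/C=C2\c3cc(OC)c(OC)c(OC)c3CC[C@@H]2O)cc1C` gives 730 nM and cannot be told apart from compound 1, while compound 2 `COc1ccc(/C=C2\c3cc(OC)c(OC)c(OC)c3CC[C@@H]2O)cc1[N+](=O)[O-]` gives 4640 nM and reads higher than compound 1 beyond the scatter.

Compound 4 `COc1ccc(/C=C2\c3cc(OC)c(OC)c(OC)c3CC[C@H]2O)cc1C(N)=O` differs from compound 1 in configuration only (the two compounds have the same atoms and bonds and differ only in configuration as drawn: 1 of 2 stereo elements differ; a stereocentre at a saturated ring carbon is drawn S in compound 1 and R in compound 4). The three measured steps bear on this only loosely, since each swaps a group on an aromatic carbon: carbamoyl to nitro (a 3.2-fold higher number from compound 1 to compound 2 (0.51 log units; beyond the scatter)), carbamoyl to methyl (a 2.0-fold lower number from compound 1 to compound 3 (0.30 log units; within the scatter)) and nitro to methyl (a 6.4-fold lower number from compound 2 to compound 3 (0.80 log units; beyond the scatter)). For the measured compounds named here, none changes a stereocentre, and the series holds no measured pair of stereoisomers, so these steps show only how far the numbers have moved so far and give no direction. For this assay the expected step is small, with its direction left open and a modest move either way possible (a 1.1-fold higher number from compound 1 to compound 4 (0.05 log units; within the scatter)). Compound 4 is expected at 1600 nM (estimated range 500 nM to 5000 nM).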

Compound 4, half-maximal inhibitory concentration: 1920 nM
Compound 4: the middle estimate sits 1.2-fold (0.08 log units) below what was measured; measured number inside the range.
By their numbers in this assay, from the lowest: compounds 3, 1 and 4 (each within the scatter of the next, the first and the last beyond it); then compound 2.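

In this assay, inverting the stereocentre at a saturated ring carbon, drawn S in compound 1 and R in compound 4, gives a 1.3-fold higher number from compound 1 to compound 4 (0.12 log units; within the scatter). In this pair, with the carbamoyl group in place, the configuration at this carbon therefore makes no readable difference to the number. Earlier steps all swapped a group on an aromatic carbon, whereas this comparison isolates the stereocentre: the fact that compounds 1 and 4 differ only in the configuration as drawn.

On these data alone, whether the same inversion is equally silent with the methyl of compound 3 or the nitro of compound 2 in place of the carbamoyl group remains open, as this is a single pair of stereoisomers. Also open, as far as these compounds go, is how the number responds if the hydroxyl on that ring carbon gives way to an amine or a methoxy group.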